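The compounds below may be only part of what the source reports. "The series", "measured", "known", "first", "only" and "open" are said of these compounds alone.

Measured compounds:
- Compound 1, `COc1ccc(C(C)N(Cc2ccc(C(C)(C)C)cc2)Cc2cc3cc(C4CC4)ccc3[nH]c2=O)cc1Cl`: > 10000 nM
- Compound 2, `COc1ccc2[nH]c(=O)c(CN(Cc3ccc(C(C)(C)C)cc3)Cc3ccc(C(F)(F)F)c(Cl)c3)cc2c1`: > 10000 nM

In a toxicity assay on MDCK cells (Canis lupus familiaris) for cytotoxicity, read by crystal violet staining, with a stated time of 48 h (on this read-out lower numbers stand for higher toxicity in this test and higher numbers for lower toxicity in this test), compound 1 gives > 10000 nM, which is a limit of the test rather than a number. Compound 2 gives > 10000 nM in this assay, again a limit. Both values therefore sit at the limit of > 10000 nM in this assay, at which 2 of the 2 values shown sit, so neither compound reaches a measurable level of toxicity in this assay, and nothing sets one apart from the other.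

Compound 3, `CC(C)(C)c1ccc(CN(Cc2ccc(C(F)(F)F)c(Cl)c2)Cc2cc3cc(C4CC4)ccc3[nH]c2=O)cc1`, has not yet been measured. It differs from compound 2 by cyclopropyl in place of methoxy on an aromatic carbon, the same cyclopropyl that compound 1 already carries. Among the measured compounds shown here, no measured pair shows this change on its own. Because both compound 1 and compound 2 rest at the limit of > 10000 nM in this assay, at which 2 of the 2 values shown sit, no shift beyond the usual scatter is expected in this assay, and the result is expected most likely to be another limit. The expected step is a step that the limit leaves unreadable from compound 2 to compound 3. For compound 3 the estimate in this assay is 20000 nM, with a range from 8000 nM to 100000 nM.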

Compound 3, half-maximal cytotoxic concentration: > 10000 nM
Compound 3: a limit, no number; the forecaster's own chance of this, stated with the estimate: 85%; the middle value does not contradict the limit.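

In this assay compound 3 gives > 10000 nM, which is a limit and not a number. No step to compound 3 from compound 1 or compound 2 can be read, because all three values stop at the same point: the limit of > 10000 nM in this assay, at which 3 of the 3 values shown sit.

The compounds shown leave open whether cyclopropyl in place of methoxy on an aromatic carbon changes toxicity in this assay.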